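Fluorocyclopropyl amide on the diazabicyclic core

The compounds below may be only part of what the source reports. "The series", "measured", "known", "first", "only" and "open" are said of these compounds alone.

Among the measured compounds shown here, compound 1 `CCCC(=O)N1CC2CC(C1)N2` has the lowest of the two numbers so far: in an assay on CHO cells for displacement of a labelled ligand from Neuronal acetylcholine receptor; alpha3/alpha6/beta2/beta3 (Homo sapiens), read by scintillation counting (a lower number here means a stronger inhibitor, a higher number a weaker inhibitor), compound 1 gives 350 nM, and compound 2 `O=C(CC1C=CCC1)N1CC2CC(C1)N2` gives 2500 nM. For the measured compounds named here, the only measured step, a 7.1-fold higher number from compound 1 to compound 2 (0.85 log units; beyond the scatter), shows that bringing a ring onto the side chain raised the number. Compound 3 `O=C([C@@H]1C[C@@H]1F)N1CC2CC(C1)N2` differs from compound 1 by 2-fluorocyclopropyl in place of propyl on a carbonyl carbon; here the ring is smaller than in compound 2 and replaces the whole propyl. A rise beyond the scatter but smaller than that step is expected, so for compound 3 the expected number is 700 nM (range 250 nM to 2500 nM), meaning a 2.0-fold higher number from compound 1 to compound 3 (0.30 log units; within the scatter).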

Compound 3, inhibition constant: 55 nM
Estimate against measurement, compound 3: 13-fold (1.10 log units) above, and the stated range ends above it.
By their numbers in this assay, from the lowest: compound 3; then compound 1; then compound 2.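

Putting 2-fluorocyclopropyl in place of propyl on this carbonyl carbon moves the number down (a 6.4-fold lower number from compound 1 to compound 3 (0.80 log units; beyond the scatter)), so a ring in this side chain does not always raise it, as the earlier step alone suggested (a 7.1-fold higher number from compound 1 to compound 2 (0.85 log units; beyond the scatter)). Compound 3 is the only compound shown with fluorine and the only one with its ring on the carbonyl carbon itself. Nothing available here accounts for the lower number.

On these data alone, whether it goes with the ring or with the fluorine stays open, and plain cyclopropyl on the same carbonyl carbon would separate the two. As far as these compounds go, the role of the two defined stereocentres also stays open, which the other stereoisomers of 2-fluorocyclopropyl would address.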